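This account rests on a few compounds, and the source may have more. Where it says the series, first, only, none or still open, it means among the compounds named here.

Compound 1 `COc1cc(/C=C/C(=O)c2cccc(NC(=O)c3ccc(Cl)c(Cl)c3)c2)ccc1O`: 5%
Compound 2 `COc1cc(/C=C/C(=O)c2cccc(NC(=O)c3cc(Cl)cc(Cl)c3)c2)ccc1O`: 51%

In a functional assay on HUVEC cells (Homo sapiens) for inhibition, tested at 5 ug/mL (on this read-out higher numbers stand for a stronger effect at the one concentration tested and lower numbers for a weaker effect), compound 2 gives 51%, the higher of the two numbers recorded, while compound 1 gives 5%. Within the data shown here, the single measured step, a number 46 percentage points higher from compound 1 to compound 2 (beyond the scatter), shows that the group on this carbonyl carbon moves the read-out strongly. Compound 3 `COC(=O)C(=O)Nc1cccc(C(=O)/C=C/c2ccc(O)c(OC)c2)c1` differs from compound 2 by methoxycarbonyl in place of 3,5-dichlorophenyl on a carbonyl carbon. Among the measured compounds shown here, no measured step covers this change, so the estimate is wide. Given the sensitivity shown by a number 46 percentage points higher from compound 1 to compound 2 (beyond the scatter), compound 3 is expected to lose ground, with a step of a number 26 percentage points lower from compound 2 to compound 3 (beyond the scatter). Compound 3 is therefore estimated at 25%, between 0% and 60%.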

Compound 3, a percentage reported as inhibition, at one concentration (the size of the read-out at that concentration, not a potency): 20%
For compound 3 the middle estimate is 5 percentage points above the measured one; the measured number falls inside the stated range.
By their numbers in this assay, from the lowest: compound 1; then compound 3; then compound 2.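

In this assay, methoxycarbonyl on this carbonyl carbon gives a number 31 percentage points lower from compound 2 to compound 3 (beyond the scatter), yet also a number 15 percentage points higher from compound 1 to compound 3 (beyond the scatter), so this group with no ring falls between the two dichlorophenyl groups. A ring on this carbonyl carbon is therefore not needed for a read-out above that of compound 1, and the placement of the chlorines decides whether a dichlorophenyl group ranks above or below methoxycarbonyl. No measured evidence accounts for these differences. On these data alone, what a carboxylic acid or a primary amide would give in place of methoxycarbonyl remains open, as does the read-out with an unsubstituted phenyl on this carbonyl carbon.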